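Adding a second chloro to a fused core: expected cytotoxicity

This account rests on a few compounds, and the source may have more. Where it says the series, first, only, none or still open, it means among the compounds named here.

Measured compounds:
compound 1 `ClCc1ccc(Cn2cnc3c(Cl)ncnc32)cc1` gives 9330 nM
compound 2 `ClCc1cccc(Cn2cnc3ncnc(Cl)c32)c1` gives 8540 nM
compound 3 `ClCc1ccc(Cn2cnc3c(Cl)nc(Cl)nc32)cc1` gives 50100 nM

All three numbers come from a functional assay on NCI-H322M cells (Homo sapiens) for cytotoxicity, read by sulforhodamine B assay, with a stated time of 48 h; on this read-out lower numbers stand for higher toxicity in this test and higher numbers for lower toxicity in this test. Compound 1 and compound 2 are built from the same atoms joined differently; the difference between the two cores is not broken down here, and their values in this assay lie within the scatter of each other, so no order between them can be claimed. Compound 3 carries one more chloro than compound 1, and that single change, (chloro in place of hydrogen on an aromatic carbon), produced a step of a 5.4-fold higher number from compound 1 to compound 3 (0.73 log units; beyond the scatter), so the added chloro went with a weaker effect on the cells.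

Compound 4 `ClCc1cccc(Cn2cnc3nc(Cl)nc(Cl)c32)c1` has not been measured in this assay. It stands to compound 2 as compound 3 stands to compound 1: the change is chloro in place of hydrogen on an aromatic carbon, and the surroundings of the new chloro are described in the same words as in the measured pair, so this is the same change made on the other core. Among the measured compounds shown here, with only one measured example of the change, the expectation rests on that example alone. A step of about the same size is expected from compound 2 to compound 4, namely a 5.3-fold higher number from compound 2 to compound 4 (0.72 log units; beyond the scatter), because the earlier pair showed a 5.4-fold higher number from compound 1 to compound 3 (0.73 log units; beyond the scatter). On this basis compound 4 is estimated at 45000 nM, with a likely range from 15000 nM to 130000 nM.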

Compound 4, concentration lethal to 50% of the cells: 52500 nM
Compound 4: the middle estimate sits 1.2-fold (0.07 log units) below what was measured; the range from low to high includes it.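

In this assay, putting a chloro in place of hydrogen on an aromatic carbon, between two ring nitrogen atoms, gave a 6.1-fold higher number from compound 2 to compound 4 (0.79 log units; beyond the scatter), so on this core too the added chloro went with a higher number, which here stands for lower toxicity in this test. Set beside the earlier step, the new one points the same way and has much the same size, so the change carried over from one core to the other: the same change on two cores in this assay, a 5.4-fold higher number (0.73 log units; beyond the scatter) from compound 1 to compound 3 and a 6.1-fold higher number (0.79 log units; beyond the scatter) from compound 2 to compound 4, 1.1-fold (0.06 log units) apart, within the scatter of two such steps. Among the compounds shown here, this rests on only two pairs of compounds in a single cell line with a single read-out, so it shows that the step held on these two cores in this test, but not that it would hold on other cores or in other cells, and it does not explain why the chloro has this effect.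

As far as these compounds go, both pairs place only a chloro at this position, so it remains open whether another group there, such as an amine, a methoxy group or a fluoro, would give a step of similar direction and size. From the compounds shown here alone, all four compounds also keep a chloromethyl group, and it remains open whether these steps would persist if a plain methyl or a hydroxymethyl group stood in its place.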